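This account rests on a few compounds, and the source may have more. Where it says the series, first, only, none or still open, it means among the compounds named here.

Measured in a functional assay on A-375 cells (Homo sapiens) for activation, with a stated time of 3 days; on this read-out lower numbers stand for an effect already at smaller amounts and higher numbers for an effect only at larger amounts of compound:
- Compound 1 `O=C(Nc1ccc(-c2cscn2)cc1)C1CCCN(C(=O)c2ccc(F)c(F)c2)C1`: > 20000 nM
- Compound 2 `O=C(Nc1ccc2scnc2c1)C1CCCN(Cc2ccc(F)c(F)c2)C1`: > 20000 nM

Compound 1 gives no number in this assay, only the limit > 20000 nM. Compound 2 is likewise reported only as a limit, > 20000 nM. For the measured compounds named here, the series so far therefore rests on (the limit of > 20000 nM in this assay, at which 2 of the 2 values shown sit), and no measured step connects the two compounds.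

Compound 3 `O=C(Nc1ccc(-c2cscn2)cc1)C1CCCN(Cc2ccc(F)cc2)C1` keeps the core of compound 1 and carries 4-fluorobenzyl in place of (3,4-difluorophenyl)carbonyl on an amine nitrogen in a ring. Going by the values given here, with no step to go on, a sizeable move toward lower numbers in this assay is expected, though with low confidence, and compound 3 may also stay at the limit. The expected change is an at least 5.0-fold lower number from compound 1 to compound 3 (0.69 log units; beyond the scatter). The estimated value for compound 3 is 4000 nM, with an expected range from 800 nM to 20000 nM.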

Compound 3, half-maximal effective concentration: 5000 nM
Compound 3: the middle estimate sits 1.3-fold (0.10 log units) below what was measured; the range from low to high includes it.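

For the compounds shown here, at the position on an amine nitrogen in a ring, 4-fluorobenzyl in place of (3,4-difluorophenyl)carbonyl gives the first readable step in this assay: an at least 4.0-fold lower number from compound 1 to compound 3 (0.60 log units; beyond the scatter). This shows that a change at this one position is enough to bring the core of compound 1 to a measurable value. The size of the step remains a lower bound, as its starting point is a limit and not a number: the limit of > 20000 nM in this assay, at which 2 of the 3 values shown sit.

The change removes the carbonyl and one fluorine together, so the compounds shown leave open which of the two matters, a question that 4-fluorobenzoyl or 3-fluoro-4-fluorobenzoyl's simpler relative, unsubstituted benzyl, would bear on. They also leave open how a longer chain between the ring nitrogen and the phenyl ring, or an amine on that ring, would read here.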